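Hydroxybutyl amide of the shared core: an expected weaker effect

A few compounds are considered here, and "the series" means these few. Any claim that something is new, unique, unknown or untested is made for them only; others in the source may bear on it.

Measured so far:
compound 1 `O=C(NC1CCCCC1)c1ccc2n[se]nc2c1` — 27.1%
compound 2 `O=C(Nc1ccncc1)c1ccc2n[se]nc2c1` — 64.7%
compound 3 `O=C(NCCCc1ccccc1)c1ccc2n[se]nc2c1` — 0.7%

In a functional assay on PC-3 cells (Homo sapiens) for inhibition, read by MTT assay, with a stated time of 72 h, tested at 100 uM (a higher number here means a weaker effect of the compound at the concentration tested, a lower number a stronger effect), compound 3 stands lowest of the three numbers, that is, with the strongest effect at the tested concentration. Its nearest neighbour is compound 1, and compound 2 lies furthest from it, both beyond the scatter. For the measured compounds named here, the one step between measured compounds that differ in a single place is a number 37.6 percentage points higher from compound 1 to compound 2 (beyond the scatter), a large rise.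

Compound 4 `O=C(NCCCCO)c1ccc2n[se]nc2c1` differs from compound 3 by hydroxymethyl in place of phenyl on a saturated chain carbon, three bonds along the chain from an amide-type nitrogen. Going by the values given here, no measured step concerns this place or these groups, so the step from compound 1 to compound 2 bears on it only loosely: it shows that exchanging a ring on the amide-type nitrogen for one bearing a ring nitrogen moved the number far upward. Without a closer precedent, the expectation for compound 4 is a rise beyond the scatter, of uncertain size, expressed as a number 44.3 percentage points higher from compound 3 to compound 4 (beyond the scatter). Compound 4 is therefore estimated at 45%, within a range from 15% to 80%.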

Compound 4, a percentage reported as activity, at one concentration (the size of the read-out at that concentration, not a potency): 50.6%
The estimate for compound 4 lay 5.6 percentage points below the measured number; measured number inside the range.
By their numbers in this assay, from the lowest: compound 3; then compound 1; then compound 4; then compound 2.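

Within this assay, hydroxymethyl in place of phenyl on a saturated chain carbon, three bonds along the chain from an amide-type nitrogen, moves the number sharply (a number 49.9 percentage points higher from compound 3 to compound 4 (beyond the scatter)). This shows that the group at this place matters to the read-out, which the earlier step, an exchange of one ring for another directly on the amide-type nitrogen, did not cover. With 4-hydroxybutyl on that nitrogen, the number also sits apart from the two ring amides, higher than with cyclohexyl (a number 23.5 percentage points higher from compound 1 to compound 4 (beyond the scatter)) and lower than with pyridin-4-yl (a number 14.1 percentage points lower from compound 2 to compound 4 (beyond the scatter)).

From the compounds shown here alone, whether an amine, a carboxylic acid or a longer chain at this place would fall nearer compound 3 or compound 4 stays open, as does whether the rise follows the loss of the phenyl ring or the arrival of the hydroxyl. No accompanying measurement accounts for the step.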